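Sulfonamide nitrogen substituents: from compound 3 to compound 4

The compounds below may be only part of what the source reports. "The series", "measured", "known", "first", "only" and "open" are said of these compounds alone.

- compound 1 `Cn1ccc2ccc(-c3cc(Nc4ccccc4S(N)(=O)=O)cc4nccnc34)cc21`: 0.5 h
- compound 2 `Cn1ccc2ccc(-c3cc(Nc4ccccc4S(=O)(=O)N4CCOCC4)cc4nccnc34)cc21`: 0.367 h
- compound 3 `CN1CCCC(NS(=O)(=O)c2ccccc2Nc2cc(-c3ccc4ccn(C)c4c3)c3nccnc3c2)C1`: 0.483 h

For the measured compounds named here, in an ADME assay on microsomes from liver (Mus musculus, strain CD-1) for metabolic stability, read by LC-MS, tested at 2 uM (a higher number here means that the compound lasts longer, a lower number that the compound disappears faster), compound 3 gives 0.483 h, and no step separates it from compound 1 or compound 2 beyond the scatter. Compound 4 `CN1CCC(NS(=O)(=O)c2ccccc2Nc2cc(-c3ccc4ccn(C)c4c3)c3nccnc3c2)C1` changes the substituent on the sulfonamide nitrogen of compound 3: 1-methylpyrrolidin-3-yl in place of 1-methylpiperidin-3-yl on a sulfonamide nitrogen. Going by the values given here, the steps that bear on this change are a 1.0-fold lower number from compound 1 to compound 3 (0.02 log units; within the scatter) and a 1.3-fold higher number from compound 2 to compound 3 (0.12 log units; within the scatter), together with a 1.4-fold lower number from compound 1 to compound 2 (0.13 log units; within the scatter). All three stay within the scatter, although none of them is a ring contraction. A small step is therefore expected, with nothing beyond the scatter in this assay: a 1.1-fold lower number from compound 3 to compound 4 (0.05 log units; within the scatter). Compound 4 is estimated at 0.43 h, with an expected range of 0.25 h to 0.75 h.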

Compound 4, half-life in the Mus musculus assay: 0.667 h
For compound 4 the middle estimate is 1.6-fold (0.19 log units) below the measured one; measured number inside the range.
By their numbers in the Mus musculus assay, from the lowest: compounds 2, 3, 1 and 4 (each within the scatter of the next).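

In the Mus musculus assay, the contraction to 1-methylpyrrolidin-3-yl gives a 1.4-fold higher number from compound 3 to compound 4 (0.14 log units; within the scatter), while the other new steps read a 1.8-fold higher number from compound 2 to compound 4 (0.26 log units; within the scatter) and a 1.3-fold higher number from compound 1 to compound 4 (0.13 log units; within the scatter), so the half-life does not separate this substituent from the earlier groups. What the earlier compounds did not show is a step beyond the scatter for a change on the sulfonamide nitrogen, and it appears in a physicochemical assay for solubility, read by spectrophotometry, measured as kinetic solubility, at pH 8, tested at 500 uM (on this read-out lower numbers stand for lower solubility and higher numbers for higher solubility), where compound 3 gives 9 ug/mL and compound 4 gives 26 ug/mL: the measured solubility of compound 3, 9 ug/mL, and of compound 4, 26 ug/mL, a 2.9-fold higher number (0.46 log units; beyond the scatter)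

Still open, going by these compounds, is how an azetidine ring or an open dimethylaminoethyl chain on the sulfonamide nitrogen would behave in the Mus musculus assay and the physicochemical assay.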